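The source may hold more compounds than are shown below. What is called first, only, known or untested is meant among the compounds shown, and "the series" means these compounds.

In an ADME assay on L6 cells (Rattus norvegicus) for cytotoxicity, read by resazurin assay, with a stated time of 72 h (on this read-out higher numbers stand for weaker inhibition and lower numbers for stronger inhibition), compound 1 `O=C1[C@H]2N=NN(Cc3nc(-c4ccc(F)cc4)no3)[C@H]2C(=O)N1c1ccccc1` gives > 100 ug/mL, which is a limit of the assay and not a number. Compound 2 `O=C1[C@H]2N=NN(Cc3nc(-c4ccc([N+](=O)[O-])cc4)no3)[C@H]2C(=O)N1c1ccccc1` gives > 100 ug/mL, which is likewise only a limit. Together they show (the limit of > 100 ug/mL in this assay, at which 2 of the 2 values shown sit). Compound 3 `O=C1[C@H]2N=NN(Cc3nc(-c4ccc(C(F)(F)F)cc4)no3)[C@H]2C(=O)N1c1ccccc1` carries trifluoromethyl in place of nitro on an aromatic carbon, para to a large group: trifluoromethyl in place of nitro on an aromatic carbon. Going by the values given here, the one measured step, a step that the two limits leave unreadable from compound 1 to compound 2, changed the same place but offers no size to carry over. In this assay, no step beyond the scatter is therefore expected, and the estimated step is a number no higher from compound 2 to compound 3 (the limit leaves the size open). Compound 3 is expected at 100 ug/mL, within an estimated range of 50 ug/mL to 200 ug/mL.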

Compound 3, half-maximal inhibitory concentration: 44.4 ug/mL
Estimate against measurement, compound 3: 2.3-fold (0.35 log units) above, and the stated range ends above it.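

In this assay, trifluoromethyl in place of nitro gives an at least 2.2-fold lower number from compound 2 to compound 3 (0.35 log units; beyond the scatter), and trifluoromethyl in place of fluoro gives an at least 2.2-fold lower number from compound 1 to compound 3 (0.35 log units; beyond the scatter). The group on this aromatic carbon can therefore move the read-out toward stronger inhibition, which the first pair could not show. The true size of both steps stays open, as each starts from a limit: the limit of > 100 ug/mL in this assay, at which 2 of the 3 values shown sit.

The compounds shown leave open how an amine, a carboxylic acid or a methoxy group on this aromatic carbon would read. They also leave open whether a change elsewhere on the shared core would shift the read-out.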